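The compounds below may be only part of what the source reports. "The series", "measured", "known", "first", "only" and "open" are said of these compounds alone.

Working notes on the series. In a functional assay on KB cells (Homo sapiens) for cytotoxicity (on this read-out higher numbers stand for weaker inhibition and lower numbers for stronger inhibition), compound 1 `O=C(Oc1ccc2c(c1)C(=O)C=CC2=O)c1ccccc1` gives 12100 nM, compound 2 `CS(=O)(=O)OC1=CC(=O)c2ccccc2C1=O` gives 7180 nM, and compound 3 `Cc1ccc(S(=O)(=O)Oc2ccc3c(c2)C(=O)C=CC3=O)cc1` gives 16400 nM. Compound 2 has the lowest number of the three; its gap to compound 1 lies within the scatter, so no order is claimed between those two, while its gap to compound 3 lies beyond the scatter. Compound 4 `CCCOC1=CC(=O)c2ccccc2C1=O` is not yet measured. It differs from compound 2 in one place: propyl in place of methylsulfonyl on an oxygen on an unsaturated carbon. For the measured compounds named here, no pair of measured compounds differing in one place exists here, so nothing in the data shows what such a change does. With all three numbers sitting close together, the expectation for compound 4 in this assay is a step no larger than the scatter, if anything toward a higher number: a 1.4-fold higher number from compound 2 to compound 4 (0.14 log units; within the scatter). Compound 4 is therefore estimated at 10000 nM, with a range from 4000 nM to 25000 nM.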

Compound 4, half-maximal inhibitory concentration: 49400 nM
Estimate against measurement, compound 4: 4.9-fold (0.69 log units) below; measured number outside the range, above it.
By their numbers in this assay, from the lowest: compounds 2, 1 and 3 (each within the scatter of the next, the first and the last beyond it); then compound 4.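

In this assay, propyl in place of methylsulfonyl on an oxygen on an unsaturated carbon gives a 6.9-fold higher number from compound 2 to compound 4 (0.84 log units; beyond the scatter) and so shows that this place responds to the group carried on the oxygen. For the compounds shown here, the three earlier numbers, which sat close together, offered no such sign, and this is the first step to read at one place. No measurement at hand accounts for the step.

Going by these compounds, how an amine or a longer alkyl chain would read in this place stays open. Also open, on these data alone, is whether the same change on the core of compound 1 would give a step of similar size.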